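The source may hold more compounds than are shown below. What is called first, only, known or untested is meant among the compounds shown, and "the series" means these compounds.

Of the compounds shown here, three of a shared series have been measured in a functional assay on CHO cells for antagonist activity at prostaglandin E2 receptor EP3 subtype (Homo sapiens), read by cAMP accumulation, with a stated time of 30 min; on this read-out lower numbers stand for stronger inhibition and higher numbers for weaker inhibition. Compound 1 `CC(C)C(/C=C1\NC(=O)NC1=O)c1ccc(-c2ccc3cccc(F)c3c2)[nH]c1=O` gives 87 nM in this assay. Compound 3 `CC(C)/C(=C1/SC(=O)NC1=O)c1ccc(-c2ccc3cccc(F)c3c2)[nH]c1=O` gives 63 nM. Compound 2 `O=C1NC(=O)/C(=C/C(c2ccc(-c3ccc4cccc(F)c4c3)[nH]c2=O)C2CCCCC2)O1` gives 8 nM, the lowest of the three numbers; its nearest neighbour is compound 3 and its furthest is compound 1, and both of those gaps lie beyond the scatter, so compound 2 stands as the most potent of the measured set.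

Compound 4 `O=C1NC(=O)/C(=C/C(c2ccccc2)c2ccc(-c3ccc4cccc(F)c4c3)[nH]c2=O)O1` has not yet been measured. It differs from compound 2 in one place: phenyl in place of cyclohexyl on a saturated chain carbon bound to an aromatic carbon and a double-bonded chain carbon. Among the measured compounds shown here, no measured pair in the set changes this group on its own, so there is no directly comparable step to lean on.

The expectation for this change is a small move toward a weaker number, close to the edge of the scatter, with the step from compound 2 to compound 4 estimated at a 2.5-fold higher number from compound 2 to compound 4 (0.40 log units; beyond the scatter). In this assay compound 4 is accordingly estimated at 20 nM, with a likely range from 6 nM to 60 nM.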

Compound 4, half-maximal inhibitory concentration: 190 nM
For compound 4 the middle estimate is 9.5-fold (0.98 log units) below the measured one; measured number outside the range, above it.
By their numbers in this assay, from the lowest: compound 2; then compounds 3 and 1 (each within the scatter of the next); then compound 4.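

In this assay the saturated chain carbon bound to an aromatic carbon and a double-bonded chain carbon proves highly sensitive to the ring it carries, with phenyl in place of cyclohexyl giving a 24-fold higher number from compound 2 to compound 4 (1.38 log units; beyond the scatter) at this one place in the structure. The two groups are alike in heavy-atom count and in carrying no hydrogen-bond donors, no hydrogen-bond acceptors and no net charge, so the only computed difference between them is that one ring is aromatic and the other is not. Nothing available bears on the reason for this step.

As far as these compounds go, whether this loss belongs to aromatic rings as such or would follow any departure from cyclohexyl remains open, and what a cyclopentyl or a pyridyl would give at this carbon is unknown. Compounds 1 and 3 carry isopropyl, but each also differs from compound 2 elsewhere, so how an open chain compares with either ring at this position also stays unsettled.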